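Swapping an aryl amide for a semicarbazide on the shared core

The source may hold more compounds than are shown below. What is called first, only, known or untested is meant among the compounds shown, and "the series" means these compounds.

Among the compounds with values here, compound 1 `COc1cc(NC(C)CCCNC(=O)Nc2ccc(C(F)(F)F)cc2)c2ncccc2c1` is the only compound here with a definite number: in a functional assay on SW-620 cells (Homo sapiens) for inhibition, read by MTT assay, with a stated time of 72 h (on this read-out higher numbers stand for weaker inhibition and lower numbers for stronger inhibition), compound 1 gives 22000 nM. Compound 2 `COc1cc(NC(C)CCCNC(=O)NNC(=O)Nc2ccc(O)cc2)c2ncccc2c1` differs from it by ((4-hydroxyphenyl)carbamoyl)amino in place of 4-(trifluoromethyl)phenyl on an amide-type nitrogen, and in this assay compound 2 reaches only the limit > 100000 nM, which is a boundary of the measurement rather than a number. That gives an at least 4.5-fold higher number from compound 1 to compound 2 (0.65 log units; beyond the scatter).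

Compound 3 `COc1cc(NC(C)CCCNC(=O)NNC(=O)Nc2ccc(F)cc2)c2ncccc2c1` is the compound still to be measured. It differs from compound 1 as follows: ((4-fluorophenyl)carbamoyl)amino in place of 4-(trifluoromethyl)phenyl on an amide-type nitrogen. This is the same kind of change as from compound 1 to compound 2, with a fluorine on the ring where compound 2 carries a hydroxyl. Within the data shown here, the one measured step that bears on it, from compound 1 to compound 2, was at least modest and pointed to weaker inhibition, ending at the limit (the limit of > 100000 nM in this assay, at which 1 of the 2 values shown sits). A comparable loss is therefore expected here, so for compound 3 the estimated step is a 3.6-fold higher number from compound 1 to compound 3 (0.56 log units; beyond the scatter). Compound 3 is expected to give about 80000 nM in this assay, within 30000 nM to 200000 nM, with a real chance that only a limit is reported.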

Compound 3, half-maximal inhibitory concentration: > 100000 nM
Compound 3: a limit, no number; the forecaster's own chance of this, stated with the estimate: 50%; at least 1.2-fold (0.09 log units) between middle value and limit.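

Placing ((4-fluorophenyl)carbamoyl)amino on the amide-type nitrogen gives an at least 4.5-fold higher number from compound 1 to compound 3 (0.65 log units; beyond the scatter) in this assay, so the loss seen with the hydroxyl-bearing ring of compound 2 also appears when that ring carries a fluorine. The value of compound 3, > 100000 nM, is a limit of the assay and not a number. Compound 2 and compound 3 both end at a limit, so the step between them cannot be read and the data cannot rank hydroxy against fluoro, and the limit now holds most of this small set: the limit of > 100000 nM in this assay, at which 2 of the 3 values shown sit.

As far as these compounds go, whether a ((4-(trifluoromethyl)phenyl)carbamoyl)amino group would also reach the limit remains open, and with it whether the loss follows the added carbamoyl and amino atoms rather than the group on the ring. Also open, from the compounds shown here alone, is whether a ring carrying a chlorine, a methoxy group or an amine on this same side chain would give a definite number in this assay, which would allow such ring groups to be compared directly.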